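The source may report more compounds than this note shows. Statements on the series, on what has been measured and on what is new or still open speak of the compounds shown alone.

compound 1 `COC(=O)/C(=C\c1ccc(OC(=O)c2ccc(OC)cc2)cc1)Sc1ccnc2cc(Cl)ccc12`: 63500 nM
compound 2 `COC(=O)/C(=C\c1ccc(OC(=O)c2cccc(OC)c2OC)cc1)Sc1ccnc2cc(Cl)ccc12`: 86600 nM

In an ADME assay on cells (Lymphocyte, Homo sapiens) for cytotoxicity, read by MTT assay, with a stated time of 48 h (on this read-out lower numbers stand for stronger inhibition and higher numbers for weaker inhibition), compound 2 gives 86600 nM and compound 1 gives 63500 nM. These two values lie within the usual scatter of each other, so neither compound can be ranked above the other. Compound 3 `COC(=O)/C(=C\c1ccc(OC(=O)c2ccc(OC)c(OC)c2OC)cc1)Sc1ccnc2cc(Cl)ccc12` differs from compound 2 in one place: methoxy in place of hydrogen on an aromatic carbon. In words, a methoxy stands in place of hydrogen on an aromatic carbon, so 2,3-dimethoxyphenyl becomes 2,3,4-trimethoxyphenyl. Within the data shown here, only one measured step bears on this change: a 1.4-fold higher number from compound 1 to compound 2 (0.13 log units; within the scatter), where 2,3-dimethoxyphenyl replaces 4-methoxyphenyl. That single step is thin evidence, but it gives no reason to expect a shift beyond the scatter in this assay, in either direction. The expected change is a 1.1-fold lower number from compound 2 to compound 3 (0.05 log units; within the scatter). For compound 3 the estimated value is 78000 nM, with an expected range from 38000 nM to 155000 nM.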

Compound 3, half-maximal inhibitory concentration: 22400 nM
Compound 3: the middle estimate sits 3.5-fold (0.54 log units) above what was measured; the whole stated range lies above it.
By their numbers in this assay, from the lowest: compound 3; then compounds 1 and 2 (each within the scatter of the next).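

In this assay, among these compounds, a methoxy on the aromatic carbon para to a large group gives a 3.9-fold lower number from compound 2 to compound 3 (0.59 log units; beyond the scatter), the first change to lie beyond the scatter. The 2,3-dimethoxyphenyl group alone had not separated compound 2 from compound 1, so this added methoxy is what brings the number down. The 2,3,4-trimethoxyphenyl group also gives a 2.8-fold lower number from compound 1 to compound 3 (0.45 log units; beyond the scatter), although compound 1 already carries a methoxy para to the same large group, so a methoxy at that place does not produce the lower number by itself in these compounds. Whether an ethoxy, a hydroxyl or an amine on that carbon would lower the number as well remains open, and the data offer no measurement that explains the drop.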